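Compound 3 to compound 4: a carbonyl enters

This account rests on a few compounds, and the source may have more. Where it says the series, first, only, none or still open, it means among the compounds named here.

In a functional assay on KMS-11 cells (Homo sapiens) for antiproliferative activity, read by CellTiter-Glo, with a stated time of 72 h (a lower number here means a stronger inhibitor, a higher number a weaker inhibitor), compound 3 `COc1ccc(C(=O)N(Cc2ccncc2)Cc2cccc(OCc3ccc(F)cc3)c2)cc1` gives 22700 nM. That value lies within the scatter of compound 1 `COc1ccc(C(=O)N(Cc2ccncc2)Cc2cccc(OCC3CCOCC3)c2)cc1` at 17700 nM and of compound 2 `COc1ccc(C(=O)N(Cc2ccncc2)Cc2cccc(OCc3ccc([N+](=O)[O-])cc3)c2)cc1` at 15400 nM.

Compound 4 `COc1ccc(C(=O)N(Cc2ccncc2)Cc2cccc(OCC(=O)c3ccc(Cl)cc3)c2)cc1` carries (4-chlorophenyl)carbonyl in place of 4-fluorophenyl on a saturated chain carbon bound to an oxygen on an aromatic ring. Among the measured compounds shown here, three measured steps bear on this change: a 1.1-fold lower number from compound 1 to compound 2 (0.06 log units; within the scatter), a 1.3-fold higher number from compound 1 to compound 3 (0.11 log units; within the scatter) and a 1.5-fold higher number from compound 2 to compound 3 (0.17 log units; within the scatter). All three stay within the scatter, though none introduces a carbonyl or a chloro group. No shift beyond the scatter is therefore expected in this assay, and the expected step is a 1.3-fold lower number from compound 3 to compound 4 (0.10 log units; within the scatter). For compound 4 the estimated value is 18000 nM, with an expected range of 8000 nM to 40000 nM.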

Compound 4, half-maximal inhibitory concentration: 18500 nM
Compound 4: middle estimate off by 1.0-fold (0.01 log units), on the low side; the range from low to high includes it.
By their numbers in this assay, from the lowest: compounds 2, 1, 4 and 3 (each within the scatter of the next).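

In this assay, (4-chlorophenyl)carbonyl on the saturated chain carbon bound to an oxygen on an aromatic ring stays level with all three earlier groups (a 1.2-fold lower number from compound 3 to compound 4 (0.09 log units; within the scatter)) (a 1.2-fold higher number from compound 2 to compound 4 (0.08 log units; within the scatter)) (a 1.0-fold higher number from compound 1 to compound 4 (0.02 log units; within the scatter)). Among the compounds shown here, this position now spans a chain carbonyl and a chloro group as well as oxan-4-yl, 4-nitrophenyl and 4-fluorophenyl, and no step among the four compounds leaves the scatter. No measurement available here explains this flat response.

The carbonyl and the chloro enter together, so their separate contributions cannot be read. As far as these compounds go, whether an amine, a carboxylic acid or a longer chain at this place would leave the scatter stays open.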